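Aryl variation at the imidazole carbon next to the ring nitrogen

This account rests on a few compounds, and the source may have more. Where it says the series, first, only, none or still open, it means among the compounds named here.

Measured so far:
compound 1 `Cc1cccc(-c2nc(C(F)(F)F)n(CC[C@@H](O)C[C@@H](O)CC(=O)O)c2-c2ccc(F)cc2)c1`, 29 nM
compound 2 `O=C(O)C[C@H](O)C[C@H](O)CCn1c(C(F)(F)F)nc(-c2cccnc2)c1-c1ccc(F)cc1`, 66 nM
compound 3 `COc1cccc(-c2c(-c3ccc(F)cc3)nc(C(F)(F)F)n2CC[C@@H](O)C[C@@H](O)CC(=O)O)c1`, 135 nM

In an assay on microsomes from liver for inhibition of 3-hydroxy-3-methylglutaryl-coenzyme A reductase (Rattus norvegicus) (a higher number here means a weaker inhibitor, a lower number a stronger inhibitor), compound 3 gives the highest number of the three; compound 1 gives 29 nM and compound 2 gives 66 nM, both beyond the scatter from compound 3. Within the data shown here, the one single-point step measured so far is a 2.3-fold higher number from compound 1 to compound 2 (0.36 log units; beyond the scatter), which concerns a different exchange at the same aromatic carbon and does not involve the methoxy group.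

Compound 4 `Cc1cc(C)cc(-c2c(-c3ccc(F)cc3)nc(C(F)(F)F)n2CC[C@@H](O)C[C@@H](O)CC(=O)O)c1` differs from compound 3 by 3,5-dimethylphenyl in place of 3-methoxyphenyl on an aromatic carbon. Among the measured compounds shown here, no measured step covers this exchange; what the numbers show is that compound 1, which carries a 3-methylphenyl group there, gives 29 nM, while compound 3 with 3-methoxyphenyl gives 135 nM. On that basis a move toward the number of compound 1 is expected for compound 4, with a step of a 2.7-fold lower number from compound 3 to compound 4 (0.43 log units; beyond the scatter) in this assay, a modest lowering beyond the scatter. Compound 4 is therefore estimated at 50 nM, with a range from 20 nM to 150 nM.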

Compound 4, half-maximal inhibitory concentration: 38 nM
For compound 4 the middle estimate is 1.3-fold (0.12 log units) above the measured one; low and high end bracket the measured number.
By their numbers in this assay, from the lowest: compounds 1, 4 and 2 (each within the scatter of the next, the first and the last beyond it); then compound 3.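

In this assay, among these compounds, the step of a 3.6-fold lower number from compound 3 to compound 4 (0.55 log units; beyond the scatter) is the first reading of a change on this aromatic carbon, which bears the aryl group next to the ring atom carrying the 6-carboxy-3,5-dihydroxyhexyl group. With the heavy-atom count unchanged, 3,5-dimethylphenyl and 3-methoxyphenyl still give clearly different numbers, so this position responds to the substituents on the aryl group and not only to its size; compounds 1 and 2 differ from this pair in the arrangement of the two aryl groups, so their step does not read onto this one. Nothing available explains the difference.

Still open, from the compounds shown here alone, is whether the change follows the loss of the methoxy group or the presence of the two methyl groups. A 3-methylphenyl, 3-chlorophenyl or 3-aminophenyl group on this same carbon would separate these readings.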